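Estimating Cytotoxicity After Changing the Side Group on the Core

The source may report more compounds than this note shows. Statements on the series, on what has been measured and on what is new or still open speak of the compounds shown alone.

Compound 1 `Cc1ccc2c(NCc3ccc(NC(=O)C4CCN(C(=O)OC(C)(C)C)CC4)cc3)nc(N(C)C)nc2c1`: in a functional assay on SV5A8 cells (Homo sapiens) for cytotoxicity (a higher number here means a weaker inhibitor, a lower number a stronger inhibitor), compound 1 reaches only the assay limit of > 4820 nM.
Compound 2 `Cc1ccc2c(NCc3ccc(NC(=O)C4CCN(Cc5ccccc5)CC4)cc3)nc(N3CCC(N4CCCC4)CC3)nc2c1`: in this assay compound 2 reaches only the assay limit of > 8090 nM.
Compound 3 `Cc1ccc2c(NCc3ccc(NC(=O)C4CCN(Cc5ccc(F)cc5Cl)CC4)cc3)nc(N(C)C)nc2c1`: in this assay compound 3 reaches only the assay limit of > 5910 nM.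

Compound 2 therefore stands at a limit, not at a number, and the same holds for the other two compounds measured, as the limit of > 4820 nM in this assay, at which 1 of the 3 values shown sits, the limit of > 5910 nM in this assay, at which 1 of the 3 values shown sits, and the limit of > 8090 nM in this assay, at which 1 of the 3 values shown sits, record. Going by the values given here, the only pair that differs in one place gives a step that the two limits leave unreadable from compound 1 to compound 3, which cannot be read because both ends sit at limits.

Compound 4 `CCN1CCN(c2nc(NCc3ccc(NC(=O)C4CCN(Cc5ccccc5)CC4)cc3)c3ccc(C)cc3n2)CC1` differs from compound 2 by 4-ethylpiperazin-1-yl in place of 4-(pyrrolidin-1-yl)piperidin-1-yl on an aromatic carbon. Among the compounds with values here, no measured step touches this position, and every value so far is a limit, so there is no readable step to build on. The expectation is that compound 4 again sits at or beyond the assay limit, with a step that the limit leaves unreadable from compound 2 to compound 4 expected to be no change beyond the scatter. Compound 4 is estimated at 9000 nM, in the range 3000 nM to 30000 nM.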

Compound 4, half-maximal inhibitory concentration: > 13000 nM
Compound 4: a limit, no number; the forecaster's own chance of this, stated with the estimate: 85%; at least 1.4-fold (0.15 log units) between middle value and limit.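

In this assay compound 4 gives > 13000 nM, which is a limit and not a number. Going by these compounds alone, compound 2 also sits at a limit, so no step between compound 2 and compound 4 can be read. The compounds shown leave open whether swapping this side group changes cytotoxicity at all.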